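The compounds below may be only part of what the source reports. "The series", "measured", "known", "first", "only" and "open" are said of these compounds alone.

In a functional assay on HT-29 cells (Homo sapiens) for antiproliferative activity, read by sulforhodamine B assay, with a stated time of 48 h (a higher number here means a weaker inhibitor, a lower number a stronger inhibitor), compound 1 `O=C1NCCN1c1ccc(S(=O)(=O)Nc2cccc(Br)c2)cc1` gives 77 nM, while compound 2 `COc1ccc(NS(=O)(=O)c2ccc(N3CCNC3=O)cc2)cc1` gives 800 nM, the higher of the two numbers and so the weaker inhibitor of this pair. Compound 3 `Cc1ccccc1NS(=O)(=O)c1ccc(N2CCNC2=O)cc1` differs from compound 2 at one place: 2-methylphenyl in place of 4-methoxyphenyl on a sulfonamide nitrogen. Going by the values given here, only one measured step bears on this site: a 10-fold higher number from compound 1 to compound 2 (1.02 log units; beyond the scatter), a large change made at that same nitrogen. Among the compounds with values here, compound 3 carries neither group from that step, so it offers only a rough scale, and no measured compound has 2-methylphenyl. A moderate move toward a lower number in this assay is therefore expected, smaller than that large step. The estimated step is a 2.7-fold lower number from compound 2 to compound 3 (0.43 log units; beyond the scatter). For compound 3, the estimated value is 300 nM, with an expected range of 70 nM to 1200 nM.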

Compound 3, half-maximal inhibitory concentration: 200 nM
The estimate for compound 3 lay 1.5-fold (0.18 log units) above the measured number; low and high end bracket the measured number.
By their numbers in this assay, from the lowest: compound 1; then compound 3; then compound 2.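

In this assay, the change on the sulfonamide nitrogen gives a 4.0-fold lower number from compound 2 to compound 3 (0.60 log units; beyond the scatter) with 2-methylphenyl in place of 4-methoxyphenyl, so this site responds to more than the swap away from 3-bromophenyl seen earlier. The 3-bromophenyl group still gives the lowest number of the three, as the comparison with 2-methylphenyl gives a 2.6-fold higher number from compound 1 to compound 3 (0.41 log units; beyond the scatter) and places 2-methylphenyl between the other two groups. Nothing available here accounts for this order.

The three rings differ both in their substituent and in where it sits, so the compounds shown cannot separate the identity of the group from its placement on the ring. As far as these compounds go, how plain phenyl, 3-methylphenyl or 2-bromophenyl, or a ring carrying an amine or a carboxylic acid, would fit into this order remains open.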